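Cytotoxicity notes: aryl for cycloalkyl on the ring nitrogen

A few compounds are considered here, and "the series" means these few. Any claim that something is new, unique, unknown or untested is made for them only; others in the source may bear on it.

Three compounds have been run through an ADME assay on HeLa cells (Homo sapiens) for cytotoxicity, read by MTT assay, with a stated time of 48 h, tested at 100 uM; a higher number here means a weaker effect of the compound at the concentration tested, a lower number a stronger effect. Compound 1 `O=c1oc(-c2ccccc2)nn1CCCCN1CCN(C2CCCCC2)CC1` gives 57%, and compound 2 `Cc1ccc(CN(C)CCCCn2nc(-c3ccccc3)oc2=O)c(C)c1` gives 22%. Compound 3 `O=C1CCc2ccccc2N1CCCCN1CCN(C2CCCCC2)CC1` gives 94%, the highest of the three numbers, lying beyond the scatter above both others.

Compound 4 `O=C1CCc2ccccc2N1CCCCN1CCN(c2ccc(F)cc2)CC1` is not yet measured. Its difference from compound 3 is a single change: 4-fluorophenyl in place of cyclohexyl on an amine nitrogen in a ring.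

For the measured compounds named here, no pair of measured compounds differs in this one place, so there is no measured step of the same kind to lean on. For compound 4 the step of a number 14 percentage points lower from compound 3 to compound 4 (beyond the scatter) in this assay is expected to be a modest downward move, at the edge of the scatter. Compound 4 is accordingly estimated at 80%, with a range from 55% to 100%.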

Compound 4, a percentage reported as activity, at one concentration (the size of the read-out at that concentration, not a potency): 70%
Compound 4: middle estimate off by 10 percentage points, on the high side; the range from low to high includes it.
By their numbers in this assay, from the lowest: compound 2; then compound 1; then compound 4; then compound 3.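

In this assay the change to 4-fluorophenyl in place of cyclohexyl gives a number 24 percentage points lower from compound 3 to compound 4 (beyond the scatter) and so marks this amine nitrogen in a ring as a place where one substituent swap moves the number beyond the scatter. No measurement on hand explains the step.

Plain phenyl or benzyl on the same nitrogen would separate the part played by the fluorine from that of the aromatic ring. Going by these compounds, whether the same swap carries over to the core of compound 1 also remains open.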